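Trading Methoxy for Chloro on an Aromatic Ring

The source may report more compounds than this note shows. Statements on the series, on what has been measured and on what is new or still open speak of the compounds shown alone.

In a physicochemical assay for lipophilicity, at pH 7.4 (on this read-out higher numbers stand for higher lipophilicity and lower numbers for lower lipophilicity), compound 1 (`Fc1ccccc1C1Cc2nccn2C1`) gives 2 and compound 2 (`COc1ccc(C2Cc3nccn3C2)cc1`) gives 2 as well, so the two stand level. Compound 3 (`Clc1ccc(C2Cc3nccn3C2)cc1`) has not been measured yet. It carries chloro in place of methoxy on an aromatic carbon, para to a group of 8 heavy atoms (chloro in place of methoxy on an aromatic carbon). Within the data shown here, no measured pair shows this swap, so the expectation rests on the structural change alone. A modest rise in this assay beyond the scatter is expected, an estimated step of a number 0.60 log units higher from compound 2 to compound 3 (beyond the scatter) in size. The estimate for compound 3 is 2.6 with 2.1 to 3.1 as its expected range.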

Compound 3, distribution coefficient: 2.6
Compound 3: the middle estimate sits on the measured number at the digits printed; the range from low to high includes it.
By their numbers in this assay, from the lowest: compounds 1 and 2 (each within the scatter of the next); then compound 3.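

Replacing methoxy with chloro at this place on the aromatic ring gives a number 0.60 log units higher from compound 2 to compound 3 (beyond the scatter) in this assay, so the read-out does respond to the group held here. This is the only pair shown that differs in one place, and the swap takes away one hydrogen-bond acceptor and one heavy atom. Nothing available explains the rise.

From the compounds shown here alone, how an amine, a carboxylic acid or a longer chain at this same place would read stays open. So does whether the same swap would give a similar step on another core.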